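Series notes: amine acylation and paw-edema inhibition

A few compounds are considered here, and "the series" means these few. Any claim that something is new, unique, unknown or untested is made for them only; others in the source may bear on it.

Going by the values given here, compound 2 `CCOC(=O)C(=O)NC1=C(C#N)C2C(N3CCCC3)CCCCN2C(=O)N1c1ccccc1` and compound 1 `N#Cc1c2n(c(=O)n(-c3ccccc3)c1=N)CCCCC2N1CCCC1` are the two compounds measured so far. In a functional assay on the whole organism (strain albino) for inhibition, with Rattus norvegicus as the target, read by paw edema, with stated times of 1 h and 3 h, at a dose of 24 mmol/kg by the intraperitoneal route (a lower number here means a weaker effect, a higher number a stronger effect of the compound at the dose given), compound 2 gives 92.4%, and in this assay compound 1 gives 94.2%; the two numbers lie within the scatter of each other, so compound 2 stands level with compound 1. Compound 3 `N#CC1=C(N)N(c2ccccc2)C(=O)N2CCCCC(N3CCCC3)C12` differs from compound 2 by hydrogen in place of (ethoxycarbonyl)carbonyl on an amine nitrogen. Among the compounds with values here, no step between measured compounds is known, so the expected step of a number 4.4 percentage points lower from compound 2 to compound 3 (within the scatter) is set at none beyond the scatter, leaning slightly lower only because compound 2 gives 92.4% and compound 1 gives 94.2%, values that already sit near the top of the range. Compound 3 is expected to give 88% in this assay, within 72% to 97%.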

Compound 3, a percentage reported as inhibition, in the whole organism at one dose (the size of the read-out at that dose, not a potency): 89.3%
The estimate for compound 3 lay 1.3 percentage points below the measured number; measured number inside the range.
By their numbers in this assay, from the lowest: compounds 3, 2 and 1 (each within the scatter of the next).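

In this assay, hydrogen in place of (ethoxycarbonyl)carbonyl on an amine nitrogen gives a number 3.1 percentage points lower from compound 2 to compound 3 (within the scatter) and so leaves the read-out level at this dose. Going by these compounds alone, the whole (ethoxycarbonyl)carbonyl group can therefore leave this position without a change that can be read, which the earlier compounds could not show. From the compounds shown here alone, whether a smaller acetyl or a benzoyl group on the same nitrogen would also stay level remains open, as does any ranking at lower doses, since a single dose near the top of the range separates little. No measurement at hand explains this result.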